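A few compounds are considered here, and "the series" means these few. Any claim that something is new, unique, unknown or untested is made for them only; others in the source may bear on it.

For the measured compounds named here, in an ADME assay on the whole organism for metabolic stability, with Rattus norvegicus as the target, at a dose of 10 mg/kg by the intraperitoneal route (on this read-out lower numbers stand for a shorter-lived compound and higher numbers for a longer-lived compound), compound 1 `COc1cc(C(=O)O)ccc1OCCCCOc1ccc(C(=O)CC(C)C)c(O)c1C` gives 0.717 h, the higher of the two numbers so far. Compound 2 `COc1ccc(C(=O)O)cc1OCCCCOc1ccc(C(=O)CC(C)C)c(O)c1C` gives 0.333 h, a gap beyond the usual scatter. Compound 3 `COc1cc(C(=O)O)ccc1OCCCCOc1ccc(C(=O)CC(C)(C)C)c(O)c1C` differs from compound 1 by one change: methyl in place of hydrogen on a saturated chain carbon bound to three saturated chain carbons. Going by the values given here, no measured pair shows this change. The expected step in this assay, a 1.3-fold higher number from compound 1 to compound 3 (0.10 log units; within the scatter), is a small rise that stays within the scatter. For compound 3 the estimated value is 0.9 h, with an expected range of 0.4 h to 2 h.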

Compound 3, half-life: 2.2 h
Compound 3: middle estimate off by 2.4-fold (0.39 log units), on the low side; the measured number lies above the stated range.
By their numbers in this assay, from the lowest: compound 2; then compound 1; then compound 3.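

Going from isobutylcarbonyl to neopentylcarbonyl gives a 3.1-fold higher number from compound 1 to compound 3 (0.49 log units; beyond the scatter) in this assay. This chain end, identical in compound 1 and compound 2, is therefore a place where a single added methyl moves the half-life beyond the scatter. Nothing at hand accounts for the rise.

Going by these compounds, whether the same change gives a similar step on the core of compound 2 stays open. So does whether a cyclopropyl group or a longer chain in place of the tert-butyl would hold the half-life of compound 3.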